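The source may hold more compounds than are shown below. What is called first, only, known or untested is meant among the compounds shown, and "the series" means these compounds.

Three compounds share one core and differ only in the ring carried on the sulfonyl sulfur. In a functional assay on SMMC-7721 cells (Homo sapiens) for antiproliferative activity, read by MTT assay, with a stated time of 72 h (a higher number here means a weaker inhibitor, a lower number a stronger inhibitor), compound 1 `CN(c1ccc2[nH]c(-c3n[nH]c4ccccc34)cc2n1)S(=O)(=O)c1ccccc1` gives 12000 nM. Compound 2 `CN(c1ccc2[nH]c(-c3n[nH]c4ccccc34)cc2n1)S(=O)(=O)c1ccc(Cl)cc1` gives 12700 nM, and compound 3 `COc1ccc(S(=O)(=O)N(C)c2ccc3[nH]c(-c4n[nH]c5ccccc45)cc3n2)cc1` gives 13000 nM. Compound 3 thus sits alongside the other two, all three numbers lying within the scatter of one another. Compound 4 `COc1ccc(OC)c(S(=O)(=O)N(C)c2ccc3[nH]c(-c4n[nH]c5ccccc45)cc3n2)c1` carries 2,5-dimethoxyphenyl in place of 4-methoxyphenyl on a sulfonyl sulfur. The two steps made on that same ring, a 1.1-fold higher number from compound 1 to compound 3 (0.03 log units; within the scatter) and a 1.0-fold higher number from compound 2 to compound 3 (0.01 log units; within the scatter), both stayed within the scatter, so a second methoxy on this ring is expected to change little. The expected step is no change at the digits printed from compound 3 to compound 4 (within the scatter), which is within the scatter. Compound 4 is therefore estimated at 13000 nM, with a likely range from 6500 nM to 26000 nM.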

Compound 4, half-maximal inhibitory concentration: 4280 nM
For compound 4 the middle estimate is 3.0-fold (0.48 log units) above the measured one; measured number below the stated range.
By their numbers in this assay, from the lowest: compound 4; then compounds 1, 2 and 3 (each within the scatter of the next).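

The ring on the sulfonyl sulfur can matter after all: 2,5-dimethoxyphenyl in place of 4-methoxyphenyl gives a 3.0-fold lower number from compound 3 to compound 4 (0.48 log units; beyond the scatter) in this assay and replacing 4-chlorophenyl gives a 3.0-fold lower number from compound 2 to compound 4 (0.47 log units; beyond the scatter) in the same assay, while replacing phenyl gives a 2.8-fold lower number from compound 1 to compound 4 (0.45 log units; beyond the scatter) as well. Each step is modest but beyond the scatter, so this ring pattern separates compound 4 from the other three. Nothing available explains the gain. From the compounds shown here alone, whether both methoxy groups are needed remains open, as does the effect of an amine or a carboxylic acid on this ring.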